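A few compounds are considered here, and "the series" means these few. Any claim that something is new, unique, unknown or untested is made for them only; others in the source may bear on it.

Compound 1 `O=C(O)COc1cccc2c1CCCC2CCC(=O)NN(c1ccccc1)c1ccccc1` carries a diphenyl hydrazide on the shared core; in an assay for inhibition of Thromboxane-A synthase (Homo sapiens), using microsomes (a lower number here means a stronger inhibitor, a higher number a weaker inhibitor), compound 1 is reported as "not active" (no number reported), so no number stands for it. Among the compounds with values here, compound 2 `CCC/C(CC1CCc2c(cccc2OCC(=O)O)C1)=N\OC(c1ccccc1)c1cccnc1` is the only member with a number: in this assay compound 2 gives 85000 nM. Compound 3 `O=C(O)COc1cccc2c1CCCC2CCC(=O)NN(c1ccccc1)c1cccnc1` differs from compound 1 by pyridin-3-yl in place of phenyl on a nitrogen on an aromatic ring. Within the data shown here, no step between measured compounds covers this change, so its size is unknown; with compound 2 as the only numbered point, weak inhibition is expected at best. Compound 3 is estimated at 50000 nM in this assay, with a range of 5000 nM to 300000 nM.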

Compound 3, half-maximal inhibitory concentration: 940000 nM
Compound 3: the middle estimate sits 19-fold (1.27 log units) below what was measured, outside the stated range (above it).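

Within the data shown here, compound 1 has no number in this assay, so no step from it to compound 3 can be read. As far as these compounds go, the size of the change from phenyl to pyridin-3-yl stays open. No supporting data bear on the result.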